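The source may report more compounds than this note shows. Statements on the series, on what has been measured and on what is new or still open speak of the compounds shown alone.

The measured compounds:
- compound 1, `COc1cccc(CNCc2c(C(=O)O)n(Cc3ccc(O)cc3)c3cc(C(C)C)ccc23)c1`: > 50000 nM
- compound 2, `COc1cccc(CNCc2c(C(=O)O)n(Cc3ccccc3)c3cc(C)ccc23)c1`: 12100 nM
- compound 3, `COc1ccc(Cn2c(C(=O)O)c(CNCc3cccc(O)c3)c3ccc(C)cc32)cc1`: > 50000 nM

All three were tested in a functional assay on Bel7402/5-FU cells (Homo sapiens) for antiproliferative activity, read by MTT assay, with a stated time of 72 h; on this read-out lower numbers stand for stronger inhibition and higher numbers for weaker inhibition. For compound 1 the result is a limit of the assay, > 50000 nM, and not a number. Compound 3 likewise stops at a limit, > 50000 nM. Going by the values given here, compound 2 is the only one that gives a number, 12100 nM. On these data alone, compound 1 therefore stands at the limit of > 50000 nM in this assay, at which 2 of the 3 values shown sit, so its true value is unknown beyond that limit.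

Compound 4, `COc1cccc(CNCc2c(C(=O)O)n(Cc3ccccc3F)c3cc(C(C)C)ccc23)c1`, has not yet been measured. It differs from compound 1 in one place: 2-fluorophenyl in place of 4-hydroxyphenyl on a saturated chain carbon bound to an aromatic nitrogen. Among the compounds with values here, no measured pair differs in only one place, so the size of this change cannot be read directly from the data. Compound 2, which also carries no hydroxyl on its benzyl group, does give a number, 12100 nM, which hints that compound 4 may fall within the measurable range. The step from compound 1 to compound 4 is expected to be an at least 3.3-fold lower number from compound 1 to compound 4 (0.52 log units; beyond the scatter). For compound 4 the estimate is 15000 nM, within 4000 nM to 60000 nM.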

Compound 4, half-maximal inhibitory concentration: 5210 nM
Beside the measured number, compound 4's estimate is 2.9-fold (0.46 log units) above it, within the range that was stated.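

Going by these compounds alone, this is the first change in one place that can be read at this position, where the group sits on a saturated chain carbon bound to an aromatic nitrogen. In this assay, 2-fluorophenyl in place of 4-hydroxyphenyl gives an at least 9.5-fold lower number from compound 1 to compound 4 (0.98 log units; beyond the scatter), so the choice of group here can bring a compound from a limit of the assay to a measured number. That size is only a minimum, because compound 1 rests at a limit and not at a number: the limit of > 50000 nM in this assay, at which 2 of the 4 values shown sit.

This single pair does not tell whether the change in activity comes from losing the hydroxyl, gaining the fluorine, or both. The compounds shown also leave open how a 4-fluorophenyl, a 2-chlorophenyl or a 2-aminophenyl group would behave at this place.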